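Replacing the aryl amide of compound 3 with an aminoalkyl chain

This account rests on a few compounds, and the source may have more. Where it says the series, first, only, none or still open, it means among the compounds named here.

Compound 1 `O=C(CCC(=O)OCCCCCCSc1ccc([N+](=O)[O-])c2nonc12)Nc1ccccc1Cl`: 330 nM
Compound 2 `COc1ccc(NC(=O)CCC(=O)OCCCCCCSc2ccc([N+](=O)[O-])c3nonc23)cc1`: 130 nM
Compound 3 `COc1ccc(NC(=O)CCC(=O)OCCCCCCSc2ccc([N+](=O)[O-])c3nonc23)cc1OC`: 360 nM

In an assay on isolated protein for inhibition of glutathione S-transferase Mu 2 (Homo sapiens), with a stated time of 10 min (on this read-out lower numbers stand for stronger inhibition and higher numbers for weaker inhibition), compound 3 gives the highest of the three numbers, yet it sits within the scatter of compound 1 and only modestly apart from compound 2. Compound 4 `CCN(CC)CCCNC(=O)CCC(=O)OCCCCCCSc1ccc([N+](=O)[O-])c2nonc12` differs from it by 3-(diethylamino)propyl in place of 3,4-dimethoxyphenyl on an amide-type nitrogen. Among the compounds with values here, no measured step covers this kind of swap; the nearest are the aryl-to-aryl changes, a 2.5-fold lower number from compound 1 to compound 2 (0.40 log units; beyond the scatter), a 1.1-fold higher number from compound 1 to compound 3 (0.04 log units; within the scatter) and a 2.8-fold higher number from compound 2 to compound 3 (0.44 log units; beyond the scatter), all modest or within the scatter. Since every variation at this amide nitrogen has moved the number only a little, compound 4 is expected to land near compound 3, with a step of about a 1.4-fold higher number from compound 3 to compound 4 (0.14 log units; within the scatter). The estimate for compound 4 is 500 nM, between 150 nM and 2000 nM.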

Compound 4, half-maximal inhibitory concentration: 440 nM
Estimate against measurement, compound 4: 1.1-fold (0.06 log units) above; low and high end bracket the measured number.
By their numbers in this assay, from the lowest: compound 2; then compounds 1, 3 and 4 (each within the scatter of the next).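

In this assay the aromatic ring on the amide-type nitrogen proves dispensable: 3-(diethylamino)propyl, which has no ring, gives a 1.2-fold higher number from compound 3 to compound 4 (0.09 log units; within the scatter) and a 1.3-fold higher number from compound 1 to compound 4 (0.12 log units; within the scatter). Only compound 2 stands apart, with a 3.4-fold higher number from compound 2 to compound 4 (0.53 log units; beyond the scatter), so the 4-methoxyphenyl group is the one substituent here separated from this chain. Nothing available accounts for these results. The compounds shown leave open whether the amine itself matters or only the chain: a plain hexyl chain, a shorter aminoalkyl chain or a carboxylic acid could separate the two.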